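Sulfonyl in place of benzyl on the ring amine nitrogen

The compounds below may be only part of what the source reports. "The series", "measured", "known", "first", "only" and "open" are said of these compounds alone.

Measured so far:
- compound 1 `COc1ccc2nccc(C3CN(C4CCN(Cc5cc6ccccc6n5C)CC4)C(=O)O3)c2c1` gives 3160 nM in an in vitro functional assay on RBL cells for antagonist activity at C-C chemokine receptor type 8 (Homo sapiens), read by FLIPR and calcium flux; a lower number here means a stronger inhibitor, a higher number a weaker inhibitor
- compound 2 `COc1ccc2nccc(C3CN(C4CCN(Cc5ccccc5Cl)CC4)C(=O)O3)c2c1` gives only a limit in this assay, < 50200 nM

Compound 2 stands at a limit and not at a number in this assay. Among the compounds with values here, the one recorded step, a step that the limit leaves unreadable from compound 1 to compound 2, cannot be read because the limit of < 50200 nM in this assay, at which 1 of the 2 values shown sits, applies, so the series gives no readable size for any change at this position.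

Compound 3 `COc1ccc2nccc(C3CN(C4CCN(S(=O)(=O)c5ccc(Cl)c(Cl)c5)CC4)C(=O)O3)c2c1` differs from compound 2 by (3,4-dichlorophenyl)sulfonyl in place of 2-chlorobenzyl on an amine nitrogen in a ring. Within the data shown here, no measured step bears on this change: the only step in the set concerns a different pair of groups on the same nitrogen and is itself unreadable. Compound 1 shows that the shared core can reach a numbered value in this assay, but nothing in the data links a sulfonyl substituent on the ring amine to that value.

Compound 3 is therefore expected to lie in a wide range, around 8000 nM, between 1500 nM and 40000 nM. The step this estimate means, a step that the limit leaves unreadable from compound 2 to compound 3, is an expectation only, since compound 2 offers no number to step from.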

Compound 3, half-maximal inhibitory concentration: < 50200 nM
Compound 3 ended at the assay's limit; the forecaster's own chance of this, stated with the estimate: 40%; the middle value lies beyond the limit too.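

In this assay compound 3 gives < 50200 nM as a limit of the assay and not a number. Within the data shown here, the steps from compound 2 to compound 3 and from compound 1 to compound 3 therefore cannot be read, and no new step comes from compound 3: the limit of < 50200 nM in this assay, at which 2 of the 3 values shown sit.

Still open, from the compounds shown here alone, is how (3,4-dichlorophenyl)sulfonyl, 2-chlorobenzyl and (1-methyl-1H-indol-2-yl)methyl compare in this assay on the amine nitrogen in a ring.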